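Adding a Second Methoxy Group on the Pyrazole-Side Ring

The compounds below may be only part of what the source reports. "The series", "measured", "known", "first", "only" and "open" are said of these compounds alone.

Three compounds share a core in which a pyrazole ring carries an aromatic ring on one side and a chalcone-like chain on the other. Compound 1 `COc1ccc(-c2cc(/C=C/C(=O)c3ccc(N)cc3)[nH]n2)cc1`, compound 2 `COc1ccc(C(=O)/C=C/c2cc(-c3cc(OC)c(OC)c(OC)c3)n[nH]2)cc1OC` and compound 3 `COc1cc(-c2cc(/C=C/C(=O)c3ccc(F)c(F)c3)[nH]n2)cc(OC)c1OC` have been tested in a functional assay on OVCAR-8 cells (Homo sapiens) for inhibition, read by sulforhodamine B assay, with a stated time of 48 h; on this read-out lower numbers stand for stronger inhibition of growth and higher numbers for weaker inhibition of growth. In this assay compound 1 gives 2440 nM, compound 2 gives 1320 nM and compound 3 gives 2880 nM. Compound 1 stands second highest of the three numbers, and its values against compound 2 and compound 3 both lie within the usual scatter, so no ordering among them can be claimed.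

The one measured step among these compounds, a 2.2-fold higher number from compound 2 to compound 3 (0.34 log units; beyond the scatter), concerns the ring on the carbonyl carbon. Compound 4 `COc1ccc(-c2cc(/C=C/C(=O)c3ccc(N)cc3)[nH]n2)cc1OC` instead differs from compound 1 on the ring attached to the pyrazole: methoxy in place of hydrogen on an aromatic carbon. Going by the values given here, no measured step touches that ring, so the only guidance is that the whole set spans a narrow range and that single changes here have moved numbers only modestly.

On that basis only a small shift is expected, with a slight lean toward a lower number; the estimated step is a 1.4-fold lower number from compound 1 to compound 4 (0.13 log units; within the scatter). Compound 4 is therefore expected to give about 1800 nM, within a range from 700 nM to 4600 nM.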

Compound 4, concentration for 50% growth inhibition: 2950 nM
Compound 4: the middle estimate sits 1.6-fold (0.21 log units) below what was measured; measured number inside the range.
By their numbers in this assay, from the lowest: compounds 2, 1, 3 and 4 (each within the scatter of the next, the first and the last beyond it).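

In this assay, going by these compounds alone, placing a methoxy group on the aromatic carbon ortho to the existing methoxy group of compound 1 gives the first direct reading for the ring attached to the pyrazole (a 1.2-fold higher number from compound 1 to compound 4 (0.08 log units; within the scatter)). This step stays within the scatter, so the measurement shows no difference between hydrogen and methoxy at this carbon, even though the new group adds 2 heavy atoms and 1 hydrogen-bond acceptor. No measurement given here accounts for this outcome.

The compounds shown leave open whether a hydroxyl group, a chlorine atom or an ethoxy group on this same carbon would move the number beyond the scatter. They also leave open whether the hydrogen-to-methoxy change would read the same way with the 3,4-difluorophenyl group of compound 3 on the carbonyl carbon, in place of the ring that compound 1 and compound 4 carry there.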